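A few compounds are considered here, and "the series" means these few. Any claim that something is new, unique, unknown or untested is made for them only; others in the source may bear on it.

Measured so far, in an assay on cells for inhibition of Palmitoleoyl-protein carboxylesterase NOTUM variant C330S (Homo sapiens), read by fluorescence, with a stated time of 40 min; on this read-out lower numbers stand for stronger inhibition and higher numbers for weaker inhibition:

- Compound 1, `O=C(O)c1c[nH]c(C(F)(F)F)c1` — in this assay compound 1 gives > 100000 nM, which is a limit of the assay rather than a number.
- Compound 2, `Cc1cccc(N2CCC(C(=O)O)C2)c1` — in this assay compound 2 gives 49000 nM.
- Compound 3, `CC(C)c1cccc(N2CCC(C(=O)O)C2)c1` — in this assay compound 3 gives 57000 nM.

For the measured compounds named here, compound 3 thus holds the higher of the two numbers so far, with compound 2 as its nearest neighbour; the step of a 1.2-fold higher number from compound 2 to compound 3 (0.07 log units; within the scatter) lies within the scatter, so the two cannot be told apart. The third value is the limit of compound 1, which is the limit of > 100000 nM in this assay, at which 1 of the 3 values shown sits.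

Compound 4, `N#Cc1cccc(N2CCC(C(=O)O)C2)c1`, is not yet measured. It differs from compound 3 in one place: cyano in place of isopropyl on an aromatic carbon. Going by the values given here, the only measured step on the shared core, from compound 2 to compound 3, exchanged one alkyl group for another and moved the number by nothing beyond the scatter; a cyano group is a different kind of substituent, and no measured step covers such an exchange. In this assay the step of a 1.1-fold lower number from compound 3 to compound 4 (0.06 log units; within the scatter) is therefore expected to be small, in no fixed direction, and compound 4 is estimated at 50000 nM, within 15000 nM to 150000 nM.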

Compound 4, half-maximal inhibitory concentration: 42000 nM
Compound 4: the middle estimate sits 1.2-fold (0.08 log units) above what was measured; low and high end bracket the measured number.
By their numbers in this assay, from the lowest: compounds 4, 2 and 3 (each within the scatter of the next). At a limit, above all of these: compound 1.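

Where the earlier step only exchanged one alkyl group for another, this change replaces isopropyl with cyano, a group of a different kind that carries a hydrogen-bond acceptor, and in this assay it still stays within the scatter (a 1.4-fold lower number from compound 3 to compound 4 (0.13 log units; within the scatter)), as does the exchange for methyl (a 1.2-fold lower number from compound 2 to compound 4 (0.07 log units; within the scatter)). On this aromatic carbon, then, compound 2, compound 3 and compound 4 cannot be told apart, so neither swapping one alkyl group for another nor moving to a nitrile has yet changed the read-out measurably. Nothing measured here offers a reason for this.

Going by these compounds, it remains open whether any other group on this carbon, such as an amine, a hydroxyl or a longer chain, would move the number beyond the scatter. On these data alone, it also remains open how the shared core would respond if its carboxylic acid gave way to an amide or an ester.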